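From Ureido to Acetamido: An Expected Step

The source may report more compounds than this note shows. Statements on the series, on what has been measured and on what is new or still open speak of the compounds shown alone.

Compound 1 `CC(C)(C)c1nc(NC#N)ncc1-c1ccccc1` sits at a limit of a functional assay on the whole organism for inhibition, with Rattus norvegicus as the target, with stated times of 1 h and 3.5 h, at a dose of 100 mg/kg by the oral route (on this read-out lower numbers stand for less inhibition and higher numbers for more inhibition at the one dose given (going by the name of the read-out)), with < 5%.
Compound 2 `CC(C)(C)c1nc(NC(N)=O)ncc1-c1ccccc1` gives 14% in this assay.

Among these two, compound 2 holds the only number; the other value is a limit, as the limit of < 5% in this assay, at which 1 of the 2 values shown sits, shows. Going by the values given here, the single measured step, a number at least 9 percentage points higher from compound 1 to compound 2 (that floor lies within the scatter), concerns carbamoyl in place of cyano on a nitrogen on an aromatic ring and says little about the change now in view. Compound 3 `CC(=O)Nc1ncc(-c2ccccc2)c(C(C)(C)C)n1` differs from compound 2 by methyl in place of amino on a carbonyl carbon, read one bond further out as ureido to acetamido. Among the compounds with values here, no measured step bears on this exchange, so compound 3 is expected to show no step beyond the scatter, no change at the digits printed from compound 2 to compound 3 (within the scatter). Compound 3 is therefore estimated at 14%, between 3% and 30%.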

Compound 3, a percentage reported as inhibition, in the whole organism at one dose (the size of the read-out at that dose, not a potency): 29%
Compound 3: the middle estimate sits 15 percentage points below what was measured; low and high end bracket the measured number.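

Methyl in place of amino on a carbonyl carbon moves the number in this assay (a number 15 percentage points higher from compound 2 to compound 3 (beyond the scatter)), so this position responds to the exchange beyond the scatter. Acetyl in place of cyano on a nitrogen on an aromatic ring also clears the scatter (a number at least 24 percentage points higher from compound 1 to compound 3 (beyond the scatter)), which the carbamoyl exchange from the same starting point did not show. Compound 1 stands at a limit, and this step is therefore only a floor: the limit of < 5% in this assay, at which 1 of the 3 values shown sits. On these data alone, whether a longer chain on the carbonyl carbon, such as propionyl, or a dimethylamino group would carry the number further stays open.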